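Pyridine nitrogen shifted on an amide anilide of a thiophene core

The source may hold more compounds than are shown below. What is called first, only, known or untested is meant among the compounds shown, and "the series" means these compounds.

Compound 1 `CC(C)n1ncc2c(C(=O)Nc3ccncc3)cc(-c3cccs3)nc21`: 6300 nM
Compound 2 `CC(C)n1ncc2c(C(=O)Nc3cc(S(N)(=O)=O)ccc3F)cc(-c3cccs3)nc21`: 25000 nM
Compound 3 `CC(C)n1ccc2c(C(=O)Nc3ccc(F)cc3)cc(-c3cccs3)nc21`: > 200000 nM

The three compounds share a core carrying a thiophen-2-yl group and an amide, and were tested in an ADME assay on LLC-MK2 cells (Macaca mulatta) for cytotoxicity, read by spectrophotometry and crystal violet staining, with a stated time of 4 days; on this read-out higher numbers stand for lower toxicity in this test and lower numbers for higher toxicity in this test. Compound 1 gives 6300 nM there, the lowest of the two numbers recorded, so it is the more toxic of the two measured compounds. Compound 2, which carries a different aryl group on the amide nitrogen, gives 25000 nM in this assay, a higher number that lies beyond the usual scatter of the test. For compound 3 the result is a limit of the assay and not a number: > 200000 nM. Within the data shown here, that limit, (the limit of > 200000 nM in this assay, at which 1 of the 3 values shown sits), is the only one among the three values.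

Compound 4 `CC(C)n1ncc2c(C(=O)Nc3cccnc3)cc(-c3cccs3)nc21` is not yet measured. It differs from compound 1 by a single change: pyridin-3-yl in place of pyridin-4-yl on an amide-type nitrogen. Among the measured compounds shown here, no pair of measured compounds differs in just one place, so no measured step guides this one. The change keeps the same atoms and only moves the ring nitrogen. The step in this assay is expected to be small, most likely within the scatter, with a mild lean toward a higher number. Compound 4 is therefore estimated at 8000 nM, within 3000 nM to 30000 nM, meaning an expected step of a 1.3-fold higher number from compound 1 to compound 4 (0.10 log units; within the scatter).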

Compound 4, half-maximal cytotoxic concentration: > 200000 nM
Compound 4: only a limit was reported; the forecaster's own chance of this, stated with the estimate: 5%; at least 25-fold (1.39 log units) between middle value and limit.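

Moving the ring nitrogen alone, from pyridin-4-yl to pyridin-3-yl on an amide-type nitrogen, gives an at least 31-fold higher number from compound 1 to compound 4 (1.50 log units; beyond the scatter), the first step in this series between two compounds that differ in one place. The earlier compounds shown here could not show that this position matters, but here two compounds with the same atoms, joined differently, lie far apart in this assay, with lower toxicity in this test for the pyridin-3-yl amide. In this assay compound 4 gives > 200000 nM, which is a limit of the assay and not a number, so the step has a lower bound but no fixed size: the limit of > 200000 nM in this assay, at which 2 of the 4 values shown sit.

The compounds shown leave open how a pyridin-2-yl group, or a plain phenyl ring with no ring nitrogen, would read on the same amide-type nitrogen, and so whether the pyridin-4-yl group of compound 1 is the exception or the pyridin-3-yl group of compound 4 is. They also leave open whether the same change would give a step of similar size on another core or with a group other than thiophen-2-yl on the shared core.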